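From carboxy to hydroxymethyl on the sulfonamide chain

The source may report more compounds than this note shows. Statements on the series, on what has been measured and on what is new or still open speak of the compounds shown alone.

- compound 1 `Cc1cc2[nH]c(=O)c(=O)[nH]c2c(N(CC(=O)O)S(C)(=O)=O)c1Cl`: 155 ng.h/mL
- compound 2 `CS(=O)(=O)N(CC(=O)O)c1c(Cl)c(Cl)cc2[nH]c(=O)c(=O)[nH]c12`: 393 ng.h/mL

In an ADME assay on the whole organism (plasma, strain Sprague-Dawley) for pharmacokinetics, with Rattus norvegicus as the target, at a dose of 5 mg/kg by the oral route (a higher number here means more compound in the circulation at the dose given, a lower number less compound in the circulation), compound 1 gives 155 ng.h/mL, the lower of the two numbers, while compound 2 gives 393 ng.h/mL. Among the measured compounds shown here, the only measured step, a 2.5-fold higher number from compound 1 to compound 2 (0.40 log units; beyond the scatter), is modest but beyond the scatter, and it is chloro in place of methyl on an aromatic carbon.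

Compound 3 `Cc1cc2[nH]c(=O)c(=O)[nH]c2c(N(CCO)S(C)(=O)=O)c1Cl` keeps the core of compound 1 and differs in the chain instead: hydroxymethyl in place of carboxy on a saturated chain carbon bound to a sulfonamide nitrogen. Here hydroxymethyl stands in place of carboxy on a saturated chain carbon bound to a sulfonamide nitrogen, which turns carboxymethyl into 2-hydroxyethyl.

For the measured compounds named here, no measured pair tests this change. The step of a 2.5-fold higher number from compound 1 to compound 2 (0.40 log units; beyond the scatter) lies elsewhere on the molecule, so it offers only a rough gauge of size and no direction. No shift beyond the scatter is therefore expected, though the margin on either side must stay wide. The expected step is a 1.2-fold higher number from compound 1 to compound 3 (0.06 log units; within the scatter). Compound 3 is estimated at 180 ng.h/mL, with an expected range from 50 ng.h/mL to 650 ng.h/mL.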

Compound 3, area under the concentration-time curve: 791 ng.h/mL
Estimate against measurement, compound 3: 4.4-fold (0.64 log units) below; the measured number lies above the stated range.
By their numbers in this assay, from the lowest: compound 1; then compounds 2 and 3 (each within the scatter of the next).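

In this assay, the chain on the sulfonamide nitrogen proves to be a place where a single exchange moves the number: hydroxymethyl in place of carboxy on the saturated chain carbon gives a 5.1-fold higher number from compound 1 to compound 3 (0.71 log units; beyond the scatter), with the core left unchanged. The earlier step, a 2.5-fold higher number from compound 1 to compound 2 (0.40 log units; beyond the scatter), showed only a change on an aromatic carbon, so the series now has a second site where the number rises, and this exchange does so with the same count of hydrogen-bond donors and acceptors on both groups and the loss of the double bond outside the aromatic rings. Nothing available here accounts for the rise, so the result stands as an observation without an explanation.

As far as these compounds go, what remains open is whether 2-hydroxyethyl in place of carboxymethyl would raise the number in the same way on the core of compound 2, which carries chloro in place of methyl. Also unsettled is how a primary amide, a methyl ether or a longer chain ending in hydroxyl would read at this place on the chain.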